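Working notes: nitro in place of hydrogen on compound 2

The source may report more compounds than this note shows. Statements on the series, on what has been measured and on what is new or still open speak of the compounds shown alone.

Of the compounds shown here, two have numbers so far in an ADME assay on Vero cells (Chlorocebus sabaeus) for cytotoxicity, read by MTT assay, with a stated time of 72 h; a higher number here means a weaker inhibitor, a lower number a stronger inhibitor. There, compound 1 (`CCC[S+]([O-])CCCCN=C=S`) gives 5640 nM and compound 2 (`[O-][S+](CCCCN=C=S)Cc1ccccc1`) gives 4850 nM. These two values lie within the usual scatter of each other, so compound 2 stands level with compound 1 and the numbers do not separate the pair.

Compound 3 (`O=[N+]([O-])c1ccc(C[S+]([O-])CCCCN=C=S)cc1`) has not yet been measured. It differs from compound 2 in one place: nitro in place of hydrogen on an aromatic carbon.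

Within the data shown here, no measured pair shows the effect of this change, so the data offer no direct guide to its size. The expectation starts from compound 2 at 4850 nM and allows a wide margin. The estimated move is a 1.2-fold lower number from compound 2 to compound 3 (0.06 log units; within the scatter) in this assay, a small one toward a lower number and not expected to pass the scatter. For compound 3 the expected value is 4200 nM, with an estimated range of 1800 nM to 9500 nM.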

Compound 3, half-maximal inhibitory concentration: 3360 nM
Beside the measured number, compound 3's estimate is 1.3-fold (0.10 log units) above it; low and high end bracket the measured number.
By their numbers in this assay, from the lowest: compounds 3, 2 and 1 (each within the scatter of the next).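

In this assay the first measured case of nitro in place of hydrogen on an aromatic carbon gives a 1.4-fold lower number from compound 2 to compound 3 (0.16 log units; within the scatter) and so does not separate the pair. This position, on a six-membered aromatic ring of carbon only and para to a large group, therefore takes a nitro group of 3 heavy atoms and 2 hydrogen-bond acceptors without a departure from compound 2 beyond the scatter, although this single step gives no trend for the position. No measured evidence bearing on the origin of this step is available in the series.

The compounds shown leave open whether an amine, a carboxylic acid or a methoxy group in place of the same hydrogen would also stay within the scatter of compound 2, or whether one of these groups would produce a step beyond it. Also open, going by these compounds, is whether a longer chain between the aromatic ring and the isothiocyanate end would leave the read-out equally unmoved, and whether the nitro group would read the same at another place on the ring.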